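Removing the Nitro Group from an Ester Side Chain

The compounds below may be only part of what the source reports. "The series", "measured", "known", "first", "only" and "open" are said of these compounds alone.

Two esters sharing one core have been measured. Compound 1 `COc1cccc(C(=O)Oc2cc3c(cc2C)[C@@H](C(C)C)CC=C3C)c1` gives 11.9% in a functional assay on MCF7 cells (Homo sapiens) for antiproliferative activity, read by sulforhodamine B assay, with a stated time of 48 h, tested at 50 uM; a lower number here means less inhibition, a higher number more inhibition at the concentration tested (going by the name of the read-out). Compound 2 `CC1=CC[C@H](C(C)C)c2cc(C)c(OC(=O)c3ccc([N+](=O)[O-])cc3)cc21` gives 72.9% in this assay, the highest of the two numbers. Among the compounds with values here, the only step measured so far, a number 61 percentage points higher from compound 1 to compound 2 (beyond the scatter), shows that the group on the carbonyl carbon matters greatly. Compound 3 `CC1=CC[C@H](C(C)C)c2cc(C)c(OC(=O)c3ccccc3)cc21` differs from compound 2 by hydrogen in place of nitro on an aromatic carbon, so the 4-nitrophenyl becomes a plain phenyl. Within the data shown here, no measured step removes a nitro group outright, but the large gain seen in a number 61 percentage points higher from compound 1 to compound 2 (beyond the scatter) suggests that the nitro group carries much of the inhibition of compound 2. The step in this assay from compound 2 to compound 3 is therefore expected to be downward and beyond the scatter, though its size is uncertain. Compound 3 is estimated to give 30% in this assay, between 10% and 60%, a change of a number 42.9 percentage points lower from compound 2 to compound 3 (beyond the scatter) that is expected rather than known.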

Compound 3, a percentage reported as inhibition, at one concentration (the size of the read-out at that concentration, not a potency): 60.7%
For compound 3 the middle estimate is 30.7 percentage points below the measured one; measured number above the stated range.
By their numbers in this assay, from the lowest: compound 1; then compound 3; then compound 2.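

Hydrogen in place of nitro gives a number 12.2 percentage points lower from compound 2 to compound 3 (beyond the scatter) in this assay and so the plain phenyl ester keeps most of the inhibition, which means a large number does not depend on the nitro group. Hydrogen in place of methoxy gives a number 48.8 percentage points higher from compound 1 to compound 3 (beyond the scatter) and this much larger step shows that most of the earlier gap between the two esters goes with the methoxy group of compound 1, not with the nitro group of compound 2. Nothing available explains why either group shifts the number.

The compounds shown leave open whether an amine or a carboxylic acid on the carbon that holds the nitro group in compound 2 would give a number closer to compound 2 or compound 3. They also leave open whether a methoxy group on that same carbon would lower the number as strongly as the methoxy group of compound 1 does.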